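The source may report more compounds than this note shows. Statements on the series, on what has been measured and on what is new or still open speak of the compounds shown alone.

In a functional assay on CCRF-CEM cells (Homo sapiens) (a lower number here means a stronger inhibitor, a higher number a weaker inhibitor), three compounds sharing one core have been measured: compound 1 `O=C(/C=C/c1ccc(F)cc1)Oc1ccc(/C=C2\CCCCC2=O)cc1` gives 14400 nM, compound 2 `O=C1CCCC/C1=C\c1ccc(OC(=O)c2ccc(Cl)cc2)cc1` gives 41000 nM, and compound 3 `Cc1ccc(C(=O)Oc2ccc(/C=C3\CCCCC3=O)cc2)cc1` gives 22700 nM. Compound 3 thus lies within the scatter of both others. Compound 4 `COc1ccc(C(=O)Oc2ccc(/C=C3\CCCCC3=O)cc2)cc1` differs from it at one place: methoxy in place of methyl on an aromatic carbon, with methoxy in place of methyl on an aromatic carbon, para to a large group. Within the data shown here, the only measured step at this place is a 1.8-fold lower number from compound 2 to compound 3 (0.26 log units; within the scatter), which swaps chloro for methyl and stays within the scatter. One small step gives limited guidance, so no change beyond the scatter is expected in this assay. The expected step is a 1.0-fold lower number from compound 3 to compound 4 (0.01 log units; within the scatter). Compound 4 is estimated at 22000 nM, with an expected range of 10000 nM to 48000 nM.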

Compound 4, half-maximal inhibitory concentration: 36100 nM
Beside the measured number, compound 4's estimate is 1.6-fold (0.22 log units) below it, within the range that was stated.
By their numbers in this assay, from the lowest: compounds 1, 3, 4 and 2 (each within the scatter of the next, the first and the last beyond it).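

In this assay, methoxy on this aromatic carbon, para to a large group, gives a 1.6-fold higher number from compound 3 to compound 4 (0.20 log units; within the scatter) and a 1.1-fold lower number from compound 2 to compound 4 (0.06 log units; within the scatter). Chloro, methyl and methoxy thus all lie within the scatter of one another here, so adding a hydrogen-bond acceptor at this place brings no change that the assay can resolve. Nothing shown accounts for these numbers.

On these data alone, it remains open whether an amine or a carboxylic acid at this place would move the number beyond the scatter. The same question stands for a longer chain such as butoxy.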